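A few compounds are considered here, and "the series" means these few. Any claim that something is new, unique, unknown or untested is made for them only; others in the source may bear on it.

Measured so far:
compound 1 `CC(C)n1cnc2c(Nc3ccccc3)nc(NCOCc3ccc(/C=C/C(=O)Nc4ccccc4N)cc3)nc21`: 41.7%
compound 2 `CC(C)n1cnc2c(Nc3cccc(Cl)c3)nc(NCOCc3ccc(/C=C/C(=O)Nc4ccccc4N)cc3)nc21`: 27.9%

In a functional assay on HCT-116 cells (Homo sapiens) for antiproliferative activity, read by CCK-8 assay, with a stated time of 72 h, tested at 8 uM (a lower number here means a weaker effect, a higher number a stronger effect of the compound at the concentration tested), compound 1 gives 41.7%, the higher of the two numbers. Compound 2 gives 27.9%, and the step of a number 13.8 percentage points lower from compound 1 to compound 2 (beyond the scatter) follows from chloro in place of hydrogen on an aromatic carbon. Compound 3 `Nc1ccccc1NC(=O)/C=C/c1ccc(COCNc2nc(Nc3ccccc3)c3ncn(C4CCCC4)c3n2)cc1` differs from compound 1 at a different site: cyclopentyl in place of isopropyl on an aromatic nitrogen. Within the data shown here, the only measured step concerns the chloro and does not touch this position, so nothing measured bears on the change. With no evidence to push the number either way, compound 3 is expected to give 42%, with a range of 26% to 58%. The step of a number 0.3 percentage points higher from compound 1 to compound 3 (within the scatter) is thus expected to stay within the scatter.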

Compound 3, a percentage reported as inhibition, at one concentration (the size of the read-out at that concentration, not a potency): 17.3%
Compound 3: middle estimate off by 24.7 percentage points, on the high side, and the stated range ends above it.
By their numbers in this assay, from the lowest: compound 3; then compound 2; then compound 1.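

Swapping the group on this ring nitrogen is not a neutral change: in this assay, cyclopentyl in place of isopropyl gives a number 24.4 percentage points lower from compound 1 to compound 3 (beyond the scatter) and is beyond the scatter. Among these compounds, the earlier compounds showed only that the chloro change moves the read-out, so this is the first sign that the group on this nitrogen matters as well. Nothing measured here explains this drop.

On these data alone, whether a methyl, an ethyl or a longer chain on this nitrogen would keep or raise the number remains open. So does whether cyclopentyl would lower the number when the chloro is also present.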